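The source may report more compounds than this note shows. Statements on the series, on what has been measured and on what is new or still open speak of the compounds shown alone.

Working notes on the series. In a functional assay on SW480 cells (Homo sapiens) for cytotoxicity, read by MTT assay, with a stated time of 72 h (on this read-out lower numbers stand for stronger inhibition and higher numbers for weaker inhibition), compound 1 `O=c1cc(CSc2nc3ccccc3s2)oc2ccc(Cl)cc12` returns only a limit of the assay, > 25000 nM. Compound 2 `Cc1ccc2oc(CSc3nnc(N)s3)cc(=O)c2c1` likewise returns only a limit in this assay, > 25000 nM. Compound 2 therefore stands at no measurable point: of the two values shown, neither is a number, and both sit at the limit of > 25000 nM in this assay, at which 2 of the 2 values shown sit. Going by the values given here, no step between measured compounds can be read, since compound 1 and compound 2 differ in more than one place and both values are limits.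

Compound 3 `Cc1ccc2oc(CSc3nnc(C)s3)cc(=O)c2c1` is not yet measured in this assay. It differs from compound 2 by methyl in place of amino on an aromatic carbon. Compound 2 sits at its limit > 25000 nM and offers no numeric anchor from which a shift could be read. The step that the limit leaves unreadable from compound 2 to compound 3 is expected to be none beyond the scatter, with compound 3 most likely reported once more as a limit rather than a number. Compound 3 is estimated at 40000 nM in this assay, within a range from 15000 nM to 120000 nM.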

Compound 3, half-maximal inhibitory concentration: > 25000 nM
Compound 3 gave a limit, no number (the forecaster's own chance of this, stated with the estimate: 80%); the middle value does not contradict the limit.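

Compound 3, like compound 2, returns only a limit and no number in this assay, so no step can be read between compound 2 and compound 3. What stays open is whether methyl in place of amino shifts cytotoxicity at all, and how far any of these compounds acts, since every value shown is the same limit: the limit of > 25000 nM in this assay, at which 3 of the 3 values shown sit.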